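Compound 3 to compound 4: a fluoro step

The source may hold more compounds than are shown below. What is called first, only, known or untested is meant among the compounds shown, and "the series" means these compounds.

Measured in a functional assay on Raji cells (Homo sapiens) for cytotoxicity, with a stated time of 72 h; on this read-out higher numbers stand for an effect only at larger amounts of compound and lower numbers for an effect already at smaller amounts:
- compound 1 `C=C[C@@](C)(/C=C/c1ccc(Nc2ccccc2)cc1)CCC=C(C)C`: > 26000 nM
- compound 2 `C=C[C@@](C)(/C=C/c1ccc(Nc2ccc(F)cc2)cc1)CCC=C(C)C`: > 26000 nM
- compound 3 `C=C[C@@](C)(/C=C/c1ccc(-c2ccccc2)cc1)CCC=C(C)C`: > 26000 nM

Compound 3 has a limit and no number, like the other two: the limit of > 26000 nM in this assay, at which 3 of the 3 values shown sit. Compound 4 `C=C[C@@](C)(/C=C/c1ccc(-c2cccc(F)c2)cc1)CCC=C(C)C` carries fluoro in place of hydrogen on an aromatic carbon, meta to a large group, so phenyl becomes 3-fluorophenyl: fluoro in place of hydrogen on an aromatic carbon. The same swap appears as a step that the two limits leave unreadable from compound 1 to compound 2. The remaining steps are a step that the two limits leave unreadable from compound 1 to compound 3 and a step that the two limits leave unreadable from compound 2 to compound 3. None of these gives a size or a direction, so no shift beyond the scatter is expected, and another limit is likely. The expected change is a step that the limit leaves unreadable from compound 3 to compound 4. For compound 4 the estimate is 30000 nM, with an expected range of 13000 nM to 60000 nM.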

Compound 4, half-maximal effective concentration: > 26000 nM
Compound 4 ended at the assay's limit; the forecaster's own chance of this, stated with the estimate: 85%; the middle value does not contradict the limit.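

Among the compounds shown here, no step from compound 1, compound 2 or compound 3 to compound 4 can be read, since all four stand at a limit and not a number: the limit of > 26000 nM in this assay, at which 4 of the 4 values shown sit. In this assay the compounds shown leave open whether any change to the shared core gives a measurable value.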